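Replacing the cyclopentyl group of compound 1

The source may hold more compounds than are shown below. What is called first, only, known or untested is meant among the compounds shown, and "the series" means these compounds.

Among the compounds with values here, in a functional assay on FaDu cells (Homo sapiens) for cytotoxicity, read by MTT assay, with a stated time of 72 h (on this read-out lower numbers stand for higher toxicity in this test and higher numbers for lower toxicity in this test), compound 1 (`COc1ccc(NC(=O)C(=O)c2cn(C3CCCC3)c3ccccc23)cn1`) gives 370 nM, the only actual number available. For compound 2 (`CC(C)n1cc(C(=O)C(=O)Nc2cccnc2)c2ccccc21`) the result is a limit of the assay, > 10000 nM. Compound 3 (`COCC(C)(C)n1cc(C(=O)C(=O)Nc2ccc(OC)nc2)c2ccccc21`) keeps the core of compound 1 but carries 1-(methoxymethyl)-1-methylethyl in place of cyclopentyl on an aromatic nitrogen. Within the data shown here, no measured step isolates this change, so only a small shift toward lower toxicity in this assay is expected, hardly beyond the usual scatter: a 1.6-fold higher number from compound 1 to compound 3 (0.21 log units; within the scatter). Compound 3 is estimated at 600 nM, with an expected range of 120 nM to 3000 nM.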

Compound 3, concentration lethal to 50% of the cells: 137 nM
Compound 3: middle estimate off by 4.4-fold (0.64 log units), on the high side; the measured number falls inside the stated range.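

In this assay, 1-(methoxymethyl)-1-methylethyl in place of cyclopentyl on the aromatic nitrogen gives a 2.7-fold lower number from compound 1 to compound 3 (0.43 log units; beyond the scatter) and so shows that this position accepts a group with no ring and with a hydrogen-bond acceptor, while toxicity in this test rises modestly rather than falling away. Nothing measured here accounts for this shift.

Both the ring and the oxygen change in this one step, so compound 3 cannot tell which of them goes with the lower number. Going by these compounds, how an amine or a longer chain on this nitrogen would read remains open.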